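From cyclopropyl to 4-(trifluoromethyl)cyclohexyl on a shared core

This account rests on a few compounds, and the source may have more. Where it says the series, first, only, none or still open, it means among the compounds named here.

Measured so far in a physicochemical assay for solubility, using the shake flask method, in phosphate buffer, measured as kinetic solubility, with a stated time of 20 h, at pH 6.5; a higher number here means a more soluble compound, a lower number a less soluble compound:
Compound 1 `FC(F)(F)c1ccc(Nc2cc3[nH]c(C4CCCC4)nc3cn2)nc1`: 145000 nM
Compound 2 `FC(F)(F)c1ccc(Nc2cc3[nH]c(C4CC4)nc3cn2)nc1`: < 5000 nM

Compound 2 gives < 5000 nM. This is a limit of the assay and not a number, so compound 2 has no exact place on the scale.

Compound 3 `FC(F)(F)c1ccc(Nc2cc3[nH]c([C@H]4CC[C@H](C(F)(F)F)CC4)nc3cn2)nc1` keeps the core of compound 2 but carries 4-(trifluoromethyl)cyclohexyl in place of cyclopropyl on an aromatic carbon.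

Going by the values given here, only one measured step bears on this change. It is an at least 29-fold lower number from compound 1 to compound 2 (1.46 log units; beyond the scatter), a large step with cyclopropyl in place of cyclopentyl at the same place. Read in reverse, it points to a higher number in this assay when cyclopropyl leaves, and a large step is possible. Compound 1 at 145000 nM carries a different group from compound 3, however, so its value is only a loose guide, and a smaller rise is expected.

The expected change is an at least 4.0-fold higher number from compound 2 to compound 3 (0.60 log units; beyond the scatter). The estimate for compound 3 is 20000 nM, with an expected range from 3000 nM to 130000 nM.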

Compound 3, solubility: < 5000 nM
Compound 3 ended at the assay's limit; the forecaster's own chance of this, stated with the estimate: 35%; middle value at least 4.0-fold (0.60 log units) away from the limit.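

In this assay compound 3 gives < 5000 nM, which is a limit of the assay and not a number. Replacing cyclopentyl at this place on the aromatic carbon with 4-(trifluoromethyl)cyclohexyl gives an at least 29-fold lower number from compound 1 to compound 3 (1.46 log units; beyond the scatter), so the drop seen earlier with cyclopropyl now appears with a second group, one that has a six-membered ring and not a three-membered one, and among the three compounds shown, only compound 1 with cyclopentyl has an exact value. The step from compound 2 to compound 3 cannot be read, as both values are limits: the limit of < 5000 nM in this assay, at which 2 of the 3 values shown sit.

Going by these compounds, how far compound 2 and compound 3 each lie from that limit, and so whether cyclopropyl and 4-(trifluoromethyl)cyclohexyl differ at all, stays open. Also open, on these data alone, is whether plain cyclohexyl, without the trifluoromethyl, or a cyclopentyl ring carrying an amine would stay near compound 1 or also end at the limit.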